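Chain length and tolerated concentration in a thiourea series

This account rests on a few compounds, and the source may have more. Where it says the series, first, only, none or still open, it means among the compounds named here.

Compound 1, `NC(=S)Nc1cccc(OCCCc2ccccc2)c1`. In an ADME assay on Ava5 cells (Homo sapiens) for cytotoxicity (a higher number here means that more compound is tolerated, a lower number that less compound is tolerated), compound 1 gives > 50000 nM, which is a limit of the assay and not a number.
Compound 2, `NC(=S)Nc1cccc(OCCCCc2ccccc2)c1`. In this assay compound 2 gives > 50000 nM, again a limit rather than a number.
Compound 3, `NC(=S)Nc1cccc(OCCCCCCc2ccccc2)c1`. In this assay compound 3 gives 28000 nM.

Compound 1 and compound 2 differ in one place: benzyl in place of phenyl on a saturated chain carbon, three bonds along the chain from an oxygen on an aromatic ring. The step between them, a step that the two limits leave unreadable from compound 1 to compound 2, cannot be sized because both values sit at the limit of > 50000 nM in this assay, at which 2 of the 3 values shown sit. Compound 3 differs from compound 1 in more than one place, and the difference between the two cores is not broken down here. Among the three, compound 3 supplies the only number; the other two values are limits.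

Compound 4, `NC(=S)Nc1cccc(OCCCCCCCc2ccccc2)c1`, has not yet been measured. It differs from compound 3 by benzyl in place of phenyl on a saturated chain carbon, six bonds along the chain from an oxygen on an aromatic ring. This is the same kind of change as that from compound 1 to compound 2, but not the same: there the place was three bonds along the chain from an oxygen on an aromatic ring, here it is six bonds along the chain from that oxygen.

For the measured compounds named here, with the earlier step unreadable, the only anchor is the value of compound 3, 28000 nM. The step of a 1.3-fold lower number from compound 3 to compound 4 (0.10 log units; within the scatter) is expected to stay within the usual scatter. Compound 4 is therefore estimated at 22000 nM, most likely between 9000 nM and 50000 nM.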

Compound 4, half-maximal cytotoxic concentration: 23000 nM
Beside the measured number, compound 4's estimate is 1.0-fold (0.02 log units) below it; low and high end bracket the measured number.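

In this assay, putting benzyl in place of phenyl, six bonds along the chain from the oxygen on the aromatic ring, gives a 1.2-fold lower number from compound 3 to compound 4 (0.09 log units; within the scatter), so on this core the two values cannot be told apart. The same kind of change three bonds along the chain from that oxygen offers nothing to compare it with, as the step there cannot be read and the values of both compounds are limits of the assay and not numbers: the limit of > 50000 nM in this assay, at which 2 of the 4 values shown sit.

This leaves a single readable case, which shows that the change can be made on the core of compound 3 without a step beyond the scatter, but does not show that the same holds on the core of compound 1 or on any other core.

The compounds shown leave open whether a chain longer than that of compound 4 would also stay within the scatter of compound 4 in this assay. They also leave open what an amine or a carboxylic acid in place of the benzyl of compound 4 would do to the tolerated concentration, since every chain shown here ends in a plain carbon ring.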